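A few compounds are considered here, and "the series" means these few. Any claim that something is new, unique, unknown or untested is made for them only; others in the source may bear on it.

Series notes. Compound 1 `COc1ccc(C(=O)CCN2CCN(c3ccc(F)cc3)CC2)cc1OC` and compound 2 `COc1ccc(C(=O)CCN2CCN(c3ccc(Cl)cc3)CC2)cc1OC` share one core; compound 3 `O=C(CCN1CCN(c2ccc(F)cc2)CC1)c1ccc(F)c(F)c1` stands on another, and the difference between the two cores is not broken down here. In an ADME assay on Vero cells (Chlorocebus sabaeus) for cytotoxicity, read by resazurin assay, with a stated time of 72 h (a lower number here means a stronger inhibitor, a higher number a weaker inhibitor), compound 1 gives 175000 nM, compound 2 gives 185000 nM and compound 3 gives 385000 nM, the highest of the three numbers. The change chloro in place of fluoro on an aromatic carbon made a step of a 1.1-fold higher number from compound 1 to compound 2 (0.02 log units; within the scatter). Compound 4 `O=C(CCN1CCN(c2ccc(F)cc2)CC1)c1ccc(F)c(Cl)c1` carries the same kind of change on the core of compound 3, (chloro in place of fluoro on an aromatic carbon); the place differs, being ortho to a fluoro group and meta to a large group rather than para to a large group, so the two changes are of the same kind, not the same. In this assay, among the measured compounds shown here, the expected step is a 1.0-fold higher number from compound 3 to compound 4 (0.02 log units; within the scatter), because the one measured instance gave a 1.1-fold higher number from compound 1 to compound 2 (0.02 log units; within the scatter). Compound 4 is thus expected near 400000 nM, between 200000 nM and 800000 nM.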

Compound 4, half-maximal inhibitory concentration: 185000 nM
Beside the measured number, compound 4's estimate is 2.2-fold (0.33 log units) above it, outside the stated range (below it).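

On the core of compound 3, chloro in place of fluoro on an aromatic carbon gives a 2.1-fold lower number from compound 3 to compound 4 (0.32 log units; beyond the scatter) in this assay. Set beside the step on the other core, the two do not separate: the same change on two cores in this assay, a 1.1-fold higher number (0.02 log units; within the scatter) from compound 1 to compound 2 and a 2.1-fold lower number (0.32 log units; beyond the scatter) from compound 3 to compound 4, 2.2-fold (0.34 log units) apart, within the scatter of two such steps. This shows no dependence of the change on the core, but it does not show that the change carries over unaltered: there are only two instances, and the place differs, para to a large group in one and ortho to a fluoro group and meta to a large group in the other.

Open, on these data alone, is whether the change, made in the same place on both cores, would give matching steps. Also open, as far as these compounds go, is how a nitrile or a carboxylic acid in that place would read in this assay.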